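Ring methyl step and microsomal clearance in the series

The compounds below may be only part of what the source reports. "The series", "measured", "known", "first", "only" and "open" are said of these compounds alone.

Measured so far:
Compound 1 `C[C@]1(O)C[C@](c2cccc(OC(F)(F)F)c2)([C@H](O)c2ccccn2)C1` gives 50 mL/min/kg in an ADME assay on liver for metabolic stability, with Liver microsome (Rattus norvegicus) as the target, read by LC-MS, using microsomes, with a stated time of 5 h; on this read-out lower numbers stand for slow clearance and higher numbers for fast clearance.
Compound 2 `O[C@H](c1ccccn1)[C@]1(c2cccc(OC(F)(F)F)c2)C[C@H](O)C1` gives 117 mL/min/kg in this assay.
Compound 3 `O[C@H](c1ccccn1)[C@]1(c2ccc(C(F)(F)F)cc2)C[C@@H](O)C1` gives 50 mL/min/kg in this assay.

The difference between the core of compound 2 and the core of compound 3 is not broken down here. On the core of compound 2, the change methyl in place of hydrogen on a saturated ring carbon produced a 2.3-fold lower number from compound 2 to compound 1 (0.37 log units; beyond the scatter). Compound 3 stands level with compound 1 at the digits read in this assay, within the scatter, and the two share the lowest number of the three; compound 2 is the only one beyond the scatter from them.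

Compound 4 `C[C@]1(O)C[C@@](c2ccc(C(F)(F)F)cc2)([C@H](O)c2ccccn2)C1` is not yet measured in this assay. It carries the same change on the core of compound 3, (methyl in place of hydrogen on a saturated ring carbon), with the place described in the same words. Among the compounds with values here, compound 4 is expected to show a 1.8-fold lower number from compound 3 to compound 4 (0.25 log units; within the scatter), a step of the size seen in a 2.3-fold lower number from compound 2 to compound 1 (0.37 log units; beyond the scatter), since only that one earlier step is available to rest on and compound 3 starts from 50 mL/min/kg. Compound 4 is therefore estimated at 28 mL/min/kg, with an expected range from 14 mL/min/kg to 60 mL/min/kg.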

Compound 4, clearance: 150 mL/min/kg
The estimate for compound 4 lay 5.4-fold (0.73 log units) below the measured number, outside the stated range (above it).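

In this assay the methyl in place of hydrogen on a saturated ring carbon gave a 3.0-fold higher number from compound 3 to compound 4 (0.48 log units; beyond the scatter), so the step seen on the core of compound 2 did not carry over to the core of compound 3 in either size or direction: the same change on two cores in this assay, a 2.3-fold lower number (0.37 log units; beyond the scatter) from compound 2 to compound 1 and a 3.0-fold higher number (0.48 log units; beyond the scatter) from compound 3 to compound 4, 7.0-fold (0.85 log units) apart, beyond the scatter of two such steps

On these two pairs, the change cannot be moved from one core to another as a fixed step, and its outcome on clearance has to be read on each core separately. The pairs do not show which difference between the two cores goes with the reversal, and they give no rule for any further core.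

The compounds shown leave open how this ring carbon behaves with a group other than methyl, such as an ethyl group or an amine. Also open, from the compounds shown here alone, is whether the reversal persists when the aryl group carries a nitrile or a chlorine in place of trifluoromethyl or trifluoromethoxy.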